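Expected Potency of a Methylphenyl Analogue Against Mythimna separata

A few compounds are considered here, and "the series" means these few. Any claim that something is new, unique, unknown or untested is made for them only; others in the source may bear on it.

Three compounds have been measured in a functional assay on the whole organism for inhibition, with Mythimna separata as the target, with a stated time of 5 days; a higher number here means that more compound is needed for the effect, a lower number that less compound is needed:

Compound 1 `CC(C)(C)n1ncc(OCc2nnc(-c3ccc(Cl)cc3)o2)c(Cl)c1=O`: 1.9 ug/mL
Compound 2 `CC(C)(C)n1ncc(OCc2nnc(-c3c(F)cccc3F)o2)c(Cl)c1=O`: 45.4 ug/mL
Compound 3 `CCCCn1ncc(OCc2nnc(-c3ccc(Cl)cc3)o2)c(Cl)c1=O`: 224 ug/mL

Compound 2 gives 45.4 ug/mL, which places it in the middle of the three: compound 1 needs far less at 1.9 ug/mL, while compound 3 needs more at 224 ug/mL.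

Compound 4 `Cc1cccc(-c2nnc(COc3cnn(C(C)(C)C)c(=O)c3Cl)o2)c1` differs from compound 2 in a single place: 3-methylphenyl in place of 2,6-difluorophenyl on an aromatic carbon.

Among the measured compounds shown here, one measured step touches the same place. Going from compound 1 to compound 2, the aryl group on the five-membered ring was changed and the result was a 24-fold higher number from compound 1 to compound 2 (1.38 log units; beyond the scatter), a large loss. The other step, a 120-fold higher number from compound 1 to compound 3 (2.07 log units; beyond the scatter), concerns the group on the ring nitrogen of the shared core and so does not speak to the aryl change directly, though it shows that single changes in this series can move the number a great deal.

For the measured compounds named here, no measured compound carries a 3-methylphenyl group, so the direction rests on the fact that compound 2 carries the aryl group that gave the weaker result. The step from compound 2 to compound 4 is expected to be a 4.5-fold lower number from compound 2 to compound 4 (0.66 log units; beyond the scatter), a gain that stays short of compound 1. Compound 4 is therefore estimated at 10 ug/mL, with a range from 2 ug/mL to 50 ug/mL.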

Compound 4, half-maximal effective concentration: 116 ug/mL
The estimate for compound 4 lay 12-fold (1.06 log units) below the measured number; measured number outside the range, above it.
By their numbers in this assay, from the lowest: compound 1; then compound 2; then compounds 4 and 3 (each within the scatter of the next).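

In this assay, putting 3-methylphenyl in place of 2,6-difluorophenyl gives a 2.6-fold higher number from compound 2 to compound 4 (0.41 log units; beyond the scatter) and no recovery toward compound 1, so the 2,6-difluorophenyl group does not mark the poor end of what this position accepts. Set against 4-chlorophenyl, the same 3-methylphenyl group gives a 61-fold higher number from compound 1 to compound 4 (1.79 log units; beyond the scatter), which means that both replacements of 4-chlorophenyl shown here, one carrying two fluorines and one carrying a single methyl, cost a large amount while the tert-butyl group on the ring nitrogen stays in place. Nothing at hand explains why these aryl groups differ so much in this whole-organism test.

Among the compounds shown here, with only three aryl groups on this core, it stays open whether the gap between compound 1 and compound 4 follows the change from chlorine to methyl or the change in where the group sits on the phenyl ring, as the step alters both at once. A 4-methylphenyl or a 3-chlorophenyl group on the same core would pull these two changes apart.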